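Series notes: from compound 3 to compound 4

This account rests on a few compounds, and the source may have more. Where it says the series, first, only, none or still open, it means among the compounds named here.

Values in an ADME assay on Vero cells (Chlorocebus sabaeus) for cytotoxicity, read by MTT assay, with a stated time of 72 h; on this read-out lower numbers stand for higher toxicity in this test and higher numbers for lower toxicity in this test:
- compound 1 `CC1(c2ccc(NC(c3ccc(Br)cc3)c3nnnn3C(C)(C)C)cc2)NC(=O)c2ccccc2N1`: > 400000 nM
- compound 2 `COc1cc(C(Nc2ccc(C3(C)NC(=O)c4ccccc4N3)cc2)c2nnnn2C(C)(C)C)cc(OC)c1OC`: "not determined" (no result reported)
- compound 3 `CC1(c2ccc(NC(c3cccc4ccccc34)c3nnnn3C(C)(C)C)cc2)NC(=O)c2ccccc2N1`: "not determined" (no result reported)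
- compound 4 `COc1ccc(C(Nc2ccc(C3(C)NC(=O)c4ccccc4N3)cc2)c2nnnn2C(C)(C)C)cc1`: not yet measured

Compound 3 stands without a number, at "not determined" (no result reported). Compound 2 is in the same position, at "not determined" (no result reported). Compound 1 reads > 400000 nM, which is a limit and not a number. That leaves the limit of > 400000 nM in this assay, at which 1 of the 3 values shown sits, as the only reference.

The change is 4-methoxyphenyl in place of naphthalen-1-yl on a saturated chain carbon bound to an aromatic carbon and a nitrogen on an aromatic ring. Going by the values given here, no measured pair shows the size of such a change, so no step beyond the scatter is expected in this assay, and no direction is assigned. The expectation leans on compound 1, whose > 400000 nM is a limit.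

Compound 4 is expected at about 400000 nM, with an estimated range from 150000 nM to 800000 nM.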

Compound 4, half-maximal cytotoxic concentration: > 400000 nM
Compound 4 gave a limit, no number (the forecaster's own chance of this, stated with the estimate: 70%); the middle value sits exactly at the limit.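

Compound 1 and compound 4 both rest at a limit and not a number, so no step between them can be read in this assay: the limit of > 400000 nM in this assay, at which 2 of the 4 values shown sit.

The compounds shown leave open whether any group at this place changes the half-maximal cytotoxic concentration at all.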